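A few compounds are considered here, and "the series" means these few. Any claim that something is new, unique, unknown or untested is made for them only; others in the source may bear on it.

Series notes. Compound 2 `COc1cc(C)cc(-c2nn(CC#N)cc2-c2ccnc(-c3ccc(N(C)C)cc3)c2)c1` in a functional assay on CCRF-CEM cells (Homo sapiens) for cytotoxicity, read by sulforhodamine B assay, with a stated time of 48 h, tested at 10 uM (on this read-out lower numbers stand for a stronger effect and higher numbers for a weaker effect at the one concentration tested), gives 10%; compound 1 `Cc1cc(O)cc(-c2nn(CC#N)cc2-c2ccnc(-c3ccc(Oc4ccccc4)cc3)c2)c1` in this assay gives 14%, and the two numbers lie within the usual scatter of each other, so neither stands apart. The next compound, compound 3 `Cc1cc(O)cc(-c2nn(CC#N)cc2-c2ccnc(-c3ccc(N(C)C)cc3)c2)c1`, differs from compound 2 by hydrogen in place of methyl on an oxygen on an aromatic ring. Going by the values given here, no step between measured compounds is available for this change; the step of a number 2 percentage points higher from compound 2 to compound 3 (within the scatter) is expected to stay within the scatter because compound 1, which already carries the 3-hydroxy-5-methylphenyl group, gives 14%. Compound 3 is therefore estimated at 12%, with a range from 4% to 22%.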

Compound 3, a percentage reported as activity, at one concentration (the size of the read-out at that concentration, not a potency): 7%
Compound 3: the middle estimate sits 5 percentage points above what was measured, and the stated range covers the measured number.
By their numbers in this assay, from the lowest: compounds 3, 2 and 1 (each within the scatter of the next).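

In this assay, hydrogen in place of methyl on an oxygen on an aromatic ring goes with a number 3 percentage points lower from compound 2 to compound 3 (within the scatter), so methoxy and hydroxy are not told apart at this position. Dimethylamino in place of phenoxy on an aromatic carbon goes with a number 7 percentage points lower from compound 1 to compound 3 (within the scatter), so these two groups are not told apart either. Nothing available gives a cause for either step. Open, as far as these compounds go, is whether a larger group on that oxygen, such as a benzyl group, would separate from these compounds. Also open, from the compounds shown here alone, is whether a carboxylic acid in place of dimethylamino would do so.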